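Shortening the selenium chain on a shared aminoquinazoline core

A few compounds are considered here, and "the series" means these few. Any claim that something is new, unique, unknown or untested is made for them only; others in the source may bear on it.

Measured compounds in a functional assay on CCRF-CEM cells (Homo sapiens) for cytotoxicity, read by MTT assay, with a stated time of 72 h; a higher number here means a weaker inhibitor of growth, a lower number a stronger inhibitor of growth:
compound 1, `CCCCC[Se]c1nc(N)c2ccccc2n1` — 34800 nM
compound 2, `CCCCC[Se]c1nc(NCc2ccccc2)c2ccccc2n1` — 34500 nM
compound 3, `CCCCC[Se]c1nc(NCc2ccc(SC)cc2)c2ccccc2n1` — 35000 nM

Compound 2 stands alongside compound 1 and compound 3 with no separation that survives the scatter: the step of a 1.0-fold lower number from compound 1 to compound 2 (0.00 log units; within the scatter) and the step of a 1.0-fold higher number from compound 2 to compound 3 (0.01 log units; within the scatter) are both within it. Neither the benzyl on the nitrogen nor the methylsulfanyl on the aromatic carbon moved the number in this assay.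

Compound 4, `C[Se]c1nc(NCc2ccccc2)c2ccccc2n1`, has not yet been measured. It differs from compound 2 by hydrogen in place of butyl on a saturated chain carbon bound to a selenium atom. Among the measured compounds shown here, no measured step touches the chain on the selenium atom; the two steps that exist concern the other end of the shared core and both read as flat. So nothing in hand argues for a shift in either direction, and the expectation for compound 4 is no step beyond the scatter, a step of a 1.0-fold higher number from compound 2 to compound 4 (0.01 log units; within the scatter) that is expected to be small. The estimate for compound 4 is 35000 nM, expected to fall between 12000 nM and 100000 nM.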

Compound 4, concentration for 50% growth inhibition: 39800 nM
The estimate for compound 4 lay 1.1-fold (0.06 log units) below the measured number; measured number inside the range.
By their numbers in this assay, from the lowest: compounds 2, 1, 3 and 4 (each within the scatter of the next).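

Among the compounds shown here, the chain on the selenium atom, untouched by the earlier steps, has now been cut from pentyl to methyl, and in this assay this gives a 1.2-fold higher number from compound 2 to compound 4 (0.06 log units; within the scatter). So at this position, the loss of the butyl leaves the number within the scatter, which extends the flat reading from the benzyl on the nitrogen and the methylsulfanyl on the aromatic carbon to the other end of the shared core, and none of the three single changes shown separates one compound from another. No accompanying measurement bears on why the number holds so steady across these changes.

The compounds shown leave open whether any group on the selenium atom other than pentyl and methyl, such as a longer chain or a chain ending in a carboxylic acid, would move the number beyond the scatter. They also leave open whether an amine on that chain, or a replacement of the selenium atom itself by sulfur, would give a step that can be told apart from these flat ones.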